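The compounds below may be only part of what the source reports. "The series", "measured", "known", "first", "only" and "open" are said of these compounds alone.

Measured so far:
- compound 1, `COc1ccc(CN(C(=O)CCl)c2cc(OC)c(OC)c(OC)c2)cc1O`: 84 nM
- compound 2, `COc1ccc(CNc2cc(OC)c(OC)c(OC)c2)cc1Br`: 29400 nM

In a functional assay on MGC-803 cells (Homo sapiens) for inhibition, read by MTT assay, with a stated time of 48 h (a lower number here means a stronger inhibitor, a higher number a weaker inhibitor), compound 1 gives 84 nM, the lowest of the two numbers recorded; compound 2 gives 29400 nM, a gap well beyond the scatter. Going by the values given here, the two measured compounds differ in more than one place, so no single step links them and nothing is known about the amide side chain on its own.

Compound 3, `COCC(=O)N(Cc1ccc(OC)c(O)c1)c1cc(OC)c(OC)c(OC)c1`, is the next compound for this assay. It differs from compound 1 in one place: methoxy in place of chloro on a saturated chain carbon bound to a carbonyl carbon. Among the compounds with values here, no measured pair shows this change, so the direction rests only on the two values above. The step from compound 1 to compound 3 is expected to be a moderate rise, a 9.5-fold higher number from compound 1 to compound 3 (0.98 log units; beyond the scatter), going beyond the scatter. Compound 3 is estimated at 800 nM, in a range from 150 nM to 5000 nM.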

Compound 3, half-maximal inhibitory concentration: 79 nM
Compound 3: middle estimate off by 10-fold (1.01 log units), on the high side; measured number outside the range, below it.
By their numbers in this assay, from the lowest: compounds 3 and 1 (each within the scatter of the next); then compound 2.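

In this assay, methoxy in place of chloro on a saturated chain carbon bound to a carbonyl carbon gives a 1.1-fold lower number from compound 1 to compound 3 (0.03 log units; within the scatter), so the two groups cannot be told apart at this place. The chloro group is thus not needed for a value of this size: compound 3, which carries methoxy there, gives 79 nM in this assay. Nothing at hand bears on why the two groups read alike.

From the compounds shown here alone, whether a longer chain, an amine or a carboxylic acid on this carbon would read the same remains open. Going by these compounds, compound 2 differs from compound 1 in more than one place, so the part played by the whole amide side chain, as distinct from the group at its end, also remains open.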